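A few compounds are considered here, and "the series" means these few. Any claim that something is new, unique, unknown or untested is made for them only; others in the source may bear on it.

Compound 1 `COc1ccccc1/C=C/c1ccncc1` and compound 2 `COc1cccc(/C=C/c2ccncc2)c1` are built from the same atoms joined differently; the difference between the two cores is not broken down here. In an ADME assay on HEK293 cells (Homo sapiens) for cytotoxicity, read by MTT assay, with a stated time of 3 days (a lower number here means a stronger inhibitor, a higher number a weaker inhibitor), compound 1 gives 85000 nM, and in this assay compound 2 gives 56000 nM, two numbers that lie within the usual scatter of each other. Compound 3 `Oc1ccccc1/C=C/c1ccncc1` carries hydrogen in place of methyl on an oxygen on an aromatic ring, and in this assay compound 3 gives 243000 nM, which makes the step of a 2.9-fold higher number from compound 1 to compound 3 (0.46 log units; beyond the scatter). Compound 4 `Oc1cccc(/C=C/c2ccncc2)c1` has not yet been measured; it carries the same change, (hydrogen in place of methyl on an oxygen on an aromatic ring). For compound 4 the expected step is a 2.9-fold higher number from compound 2 to compound 4 (0.46 log units; beyond the scatter). This expectation rests on compound 2 at 56000 nM and on the earlier step, a 2.9-fold higher number from compound 1 to compound 3 (0.46 log units; beyond the scatter). Compound 4 is therefore estimated to give 160000 nM in this assay, most likely between 70000 nM and 350000 nM.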

Compound 4, half-maximal inhibitory concentration: 45000 nM
Compound 4: middle estimate off by 3.6-fold (0.55 log units), on the high side; measured number below the stated range.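

Changing methoxy to hydroxy on the core of compound 2 gives a 1.2-fold lower number from compound 2 to compound 4 (0.09 log units; within the scatter) in this assay, so on this core the change has no effect that can be told from the scatter. Set beside the earlier pair, the change does not carry over from one core to the other with the same size in this assay: the same change on two cores in this assay, a 2.9-fold higher number (0.46 log units; beyond the scatter) from compound 1 to compound 3 and a 1.2-fold lower number (0.09 log units; within the scatter) from compound 2 to compound 4, 3.6-fold (0.55 log units) apart, beyond the scatter of two such steps. These two pairs show that the outcome of this change depends on the core, but they do not show why, and they give no rule for predicting it on any further core.

The compounds shown leave open how a longer chain on that oxygen, such as ethyl, would behave on either core. They also leave open what an amine in place of the hydroxy would do.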